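A few compounds are considered here, and "the series" means these few. Any claim that something is new, unique, unknown or untested is made for them only; others in the source may bear on it.

Compound 1 `CC(C)CCn1nc(CC2CCC2)c(O)c(C2=NS(=O)(=O)c3cc(NS(C)(=O)=O)ccc3N2)c1=O` and compound 2 `C/C(=C\c1nn(CCC(C)C)c(=O)c(C2=NS(=O)(=O)c3cc(NS(C)(=O)=O)ccc3N2)c1O)C(F)(F)F` share the same core and isopentyl group, and differ in one substituent on an aromatic carbon. In an ADME assay on Huh-7 cells (Homo sapiens) for cytotoxicity, with a stated time of 72 h (a higher number here means that more compound is tolerated, a lower number that less compound is tolerated), compound 1 gives > 33000 nM, which is a limit of the assay and not a number. Compound 2 gives > 33000 nM, also a limit, so no exact number places it. The evidence so far is the limit of > 33000 nM in this assay, at which 2 of the 2 values shown sit. Within the data shown here, the only measured step is therefore a step that the two limits leave unreadable from compound 1 to compound 2, and it gives no size to carry forward.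

Compound 3 `CCC(C)(C)c1nn(CCC(C)C)c(=O)c(C2=NS(=O)(=O)c3cc(NS(C)(=O)=O)ccc3N2)c1O` changes the same substituent again: 1,1-dimethylpropyl in place of 2-(trifluoromethyl)prop-1-en-1-yl on an aromatic carbon. The 1,1-dimethylpropyl group has not been tested in this series, so the two earlier compounds offer only a loose guide. The closest reference is compound 2, at its limit of > 33000 nM, so no step beyond the usual scatter is expected in this assay, in either direction. The expected step is a number no higher from compound 2 to compound 3 (the limit leaves the size open), and the result will probably be reported as a limit again. For compound 3, the estimated value is 33000 nM, with an expected range from 18000 nM to 33000 nM.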

Compound 3, half-maximal cytotoxic concentration: > 1000 nM
Compound 3: only a limit was reported; the forecaster's own chance of this, stated with the estimate: 85%; the middle value is on the limit's open side.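

In this assay compound 3 gives > 1000 nM, which is a limit of the assay and not a number. Among these compounds, with compound 1, compound 2 and compound 3 all reported only as limits, no step among them can be read. The compounds shown leave open what exact concentration each one reaches and whether swapping the substituent changes it at all.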